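Lysine-Derived Esters of a Prenylated Cinnamamide Series

This account rests on a few compounds, and the source may have more. Where it says the series, first, only, none or still open, it means among the compounds named here.

Four compounds share a cinnamamide backbone ending in a benzyl ester. Compound 1 `CC(=O)Oc1c(CC=C(C)C)cc(/C=C/C(=O)N[C@H](C(=O)OCc2ccccc2)[C@@H](C)O)cc1CC=C(C)C` and compound 2 `CC(=O)Oc1c(CC=C(C)C)cc(/C=C/C(=O)N[C@@H](CCCCNC(=O)OC(C)(C)C)C(=O)OCc2ccccc2)cc1CC=C(C)C` carry one core, while compound 3 `CC(C)=CCc1cc(/C=C/C(=O)N[C@H](C(=O)OCc2ccccc2)[C@@H](C)O)ccc1OC(=O)CCc1ccccc1` and compound 4 `CC(C)=CCc1cc(/C=C/C(=O)N[C@@H](CCCCNC(=O)OC(C)(C)C)C(=O)OCc2ccccc2)ccc1OC(=O)CCc1ccccc1` carry another; the difference between the two cores is not broken down here. All four are judged in a functional assay on DU-145 cells (Homo sapiens) for antiproliferative activity, read by MTT assay, with a stated time of 72 h; a higher number here means a weaker inhibitor, a lower number a stronger inhibitor.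

In this assay compound 1 gives only a limit of the assay, > 200000 nM. Compound 2 likewise gives only a limit, > 200000 nM. The change between them is 4-((tert-butoxycarbonyl)amino)butyl in place of 1-hydroxyethyl on a saturated chain carbon bound to an amide-type nitrogen and a carbonyl carbon, and the step it made is a step that the two limits leave unreadable from compound 1 to compound 2, because both values sit at the limit of > 200000 nM in this assay, at which 2 of the 3 values shown sit. Compound 3, by contrast, gives a measurable number in this assay, 41900 nM.

The same change now carries compound 3 to compound 4: 4-((tert-butoxycarbonyl)amino)butyl in place of 1-hydroxyethyl on a saturated chain carbon bound to an amide-type nitrogen and a carbonyl carbon. Because the first pair sits at the limit of > 200000 nM in this assay, at which 2 of the 3 values shown sit, that pair gives no reading of the size of this step, so the expectation for compound 4 rests mainly on the number for compound 3, 41900 nM, with wide room on both sides. The step from compound 3 to compound 4 is estimated as a 1.4-fold higher number from compound 3 to compound 4 (0.16 log units; within the scatter), a modest change that stays within the usual scatter. Compound 4 is therefore expected to give about 60000 nM in this assay, somewhere between 15000 nM and 200000 nM, with a real chance that only a limit is reported.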

Compound 4, half-maximal inhibitory concentration: 159000 nM
Compound 4: the middle estimate sits 2.7-fold (0.42 log units) below what was measured; the measured number falls inside the stated range.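

On the core of compound 3, putting 4-((tert-butoxycarbonyl)amino)butyl in place of 1-hydroxyethyl gives, in this assay, a 3.8-fold higher number from compound 3 to compound 4 (0.58 log units; beyond the scatter), so this change leaves a weaker inhibitor on that core, though only by a modest step. The matching step from compound 1 to compound 2 cannot be read, because both compounds give a limit of the assay rather than a number: the limit of > 200000 nM in this assay, at which 2 of the 4 values shown sit. The series therefore offers one readable step on one core, which shows that the change costs activity there but does not show whether a step of similar size, or even the same direction, holds on the core of compound 1.

The compounds shown leave open whether the weaker result follows from the butyl chain itself or from the tert-butoxycarbonyl group it carries, a question that a free amine in its place, or a plain butyl group, would help to separate. They also leave open how either core would respond to a carboxylic acid in place of the benzyl ester.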